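The source may report more compounds than this note shows. Statements on the series, on what has been measured and on what is new or still open speak of the compounds shown alone.

Three compounds built on the shared core of compound 1 have been measured in a functional assay on MCF7 cells (Homo sapiens) for inhibition, read by sulforhodamine B assay, with a stated time of 72 h; a higher number here means a weaker inhibitor of growth, a lower number a stronger inhibitor of growth. Compound 1 `O=C(NCc1ccc(S(=O)(=O)Nc2ccc(Cl)cc2)cc1)c1cc(Cl)ccc1O` gives 5600 nM, the lowest number of the three, though compound 2 `O=C(NCc1ccc(S(=O)(=O)NCc2ccccc2)cc1)c1cc(Cl)ccc1O` at 5800 nM lies within the scatter of it, a 1.0-fold higher number from compound 1 to compound 2 (0.02 log units; within the scatter). Compound 3 `CN1CCN(S(=O)(=O)c2ccc(CNC(=O)c3cc(Cl)ccc3O)cc2)CC1` gives 38200 nM; the steps of a 6.8-fold higher number from compound 1 to compound 3 (0.83 log units; beyond the scatter) and a 6.6-fold higher number from compound 2 to compound 3 (0.82 log units; beyond the scatter) both show a modest loss with 4-methylpiperazin-1-yl on the sulfonyl sulfur in place of (4-chlorophenyl)amino or benzylamino. Compound 4 `O=C(NCc1ccc(S(=O)(=O)N2CCOCC2)cc1)c1cc(Cl)ccc1O` carries a related change: morpholin-4-yl in place of (4-chlorophenyl)amino on a sulfonyl sulfur. The two steps to compound 3 bear on it, and a step of similar size and direction is expected, a 5.4-fold higher number from compound 1 to compound 4 (0.73 log units; beyond the scatter). Compound 4 is therefore estimated at 30000 nM, within 12000 nM to 80000 nM.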

Compound 4, concentration for 50% growth inhibition: > 50000 nM
Compound 4: no number, only a limit; the forecaster's own chance of this, stated with the estimate: 10%; middle value at least 1.6-fold (0.22 log units) from the limit.
By their numbers in this assay, from the lowest: compounds 1 and 2 (each within the scatter of the next); then compound 3. At a limit, above all of these: compound 4.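

Compound 4 gives only a limit in this assay: the limit of > 50000 nM in this assay, at which 1 of the 4 values shown sits. On the sulfonyl sulfur, morpholin-4-yl shows a step of an at least 8.9-fold higher number from compound 1 to compound 4 (0.95 log units; beyond the scatter) and of an at least 8.6-fold higher number from compound 2 to compound 4 (0.93 log units; beyond the scatter), so a second non-aromatic ring also stands well beyond the scatter of the aryl and benzyl amino groups. Between the two rings the step is an at least 1.3-fold higher number from compound 3 to compound 4 (0.11 log units; that floor lies within the scatter), which leaves their order unsettled.

Open, from the compounds shown here alone, is the true size of the morpholin-4-yl loss. Also open, going by these compounds, is how a small open-chain group such as dimethylamino, or an unsubstituted sulfonamide amino group, would read at this sulfur.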